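The source may report more compounds than this note shows. Statements on the series, on what has been measured and on what is new or still open speak of the compounds shown alone.

Three compounds have been measured in a functional assay on CHO cells for antagonist activity at prostaglandin E2 receptor EP4 subtype (Homo sapiens), read by calcium flux, with a stated time of 15 min; on this read-out lower numbers stand for stronger inhibition and higher numbers for weaker inhibition:

Compound 1, `Cc1nnn(Cc2ccc(C(F)(F)F)cc2)c1C(=O)N[C@@H](C)c1ccc(C(=O)O)cc1`, gives only > 10000 nM.
Compound 2, `CCCc1nnn(Cc2ccc(C(F)(F)F)cc2)c1C(=O)N[C@@H](C)c1ccc(C(=O)O)cc1`, gives 68.8 nM.
Compound 3, `C[C@H](NC(=O)c1c(C2CCCCC2)nnn1Cc1ccc(C(F)(F)F)cc1)c1ccc(C(=O)O)cc1`, gives 161 nM.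

Compound 1 sits at the limit of > 10000 nM in this assay, at which 1 of the 3 values shown sits, which is a limit of the assay and not a number. Of the two numbers shown, compound 3 holds the higher one, with compound 2 as its nearest neighbour: a 2.3-fold higher number from compound 2 to compound 3 (0.37 log units; beyond the scatter). Compound 4, `C[C@H](NC(=O)c1c(C2=CCCCC2)nnn1Cc1ccc(C(F)(F)F)cc1)c1ccc(C(=O)O)cc1`, has not yet been measured; it differs from compound 3 by cyclohex-1-en-1-yl in place of cyclohexyl on an aromatic carbon. Going by the values given here, two measured steps concern the same aromatic carbon of the shared core: an at least 62-fold lower number from compound 1 to compound 3 (1.79 log units; beyond the scatter) and a 2.3-fold higher number from compound 2 to compound 3 (0.37 log units; beyond the scatter). Both were large, but each exchanged the group there for one of a different chain or ring, whereas the change to compound 4 keeps the six-membered carbon ring and adds only one double bond. A step within the scatter is therefore expected in this assay, with no firm direction: a 1.2-fold lower number from compound 3 to compound 4 (0.06 log units; within the scatter). Compound 4 is estimated at 140 nM, with a range from 50 nM to 400 nM.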

Compound 4, half-maximal inhibitory concentration: 183 nM
Compound 4: middle estimate off by 1.3-fold (0.12 log units), on the low side; low and high end bracket the measured number.
By their numbers in this assay, from the lowest: compound 2; then compounds 3 and 4 (each within the scatter of the next). At a limit, above all of these: compound 1.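

In this assay cyclohex-1-en-1-yl and cyclohexyl cannot be told apart at this aromatic carbon, so adding the double bond to the six-membered carbon ring has no effect beyond the scatter (a 1.1-fold higher number from compound 3 to compound 4 (0.06 log units; within the scatter)). Like cyclohexyl, cyclohex-1-en-1-yl gives a higher number than propyl (a 2.7-fold higher number from compound 2 to compound 4 (0.42 log units; beyond the scatter)) and a far lower one than methyl (an at least 54-fold lower number from compound 1 to compound 4 (1.73 log units; beyond the scatter)), so among these groups neither carbon ring matches propyl. The step from methyl rests on compound 1, whose value is a limit of the assay and not a number: the limit of > 10000 nM in this assay, at which 1 of the 4 values shown sits.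

From the compounds shown here alone, it remains open how an aromatic phenyl ring or a six-membered ring holding oxygen or nitrogen, such as tetrahydropyran or piperidine, would read at this carbon. Going by these compounds, whether a longer chain such as butyl would give a lower number than propyl also remains open.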